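The source may hold more compounds than are shown below. What is called first, only, known or untested is meant among the compounds shown, and "the series" means these compounds.

Working notes on the series

Compound 1, `C[C@H](NC(=O)Nc1ccccc1C(C)(C)C)c1ccccc1`, gives in an ADME assay on the whole organism with Oryza sativa as the target, tested at 10 uM (a higher number here means a weaker effect of the compound at the concentration tested, a lower number a stronger effect), a read-out of 100%. Compound 2, `C[C@H](NC(=O)Nc1ccccc1Cl)c1ccccc1`, gives in this assay a read-out of 106%. Within the data shown here, the only measured step in the set is a number 6 percentage points higher from compound 1 to compound 2 (within the scatter); it is the sole comparison available and it lies inside the usual scatter of this kind of measurement. Compound 2 therefore stands alongside compound 1 on the two numbers shown, with no separation between them that can be read as real.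

Compound 3, `C[C@H](NC(=O)Nc1ccccc1Br)c1ccccc1`, is the next member and differs from compound 2 only as follows: bromo in place of chloro on an aromatic carbon. Among the measured compounds shown here, the one step that bears on this change, from compound 1 to compound 2, exchanged one substituent on the same aromatic carbon for another and produced no movement beyond the scatter. A second exchange of one halogen for another at that carbon is expected to behave in the same way, so the step of a number 3 percentage points lower from compound 2 to compound 3 (within the scatter) is expected to stay within the scatter. For compound 3 the estimate in this assay is 103%, with a range from 88% to 118%.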

Compound 3, a percentage reported as activity, at one concentration (the size of the read-out at that concentration, not a potency): 102%
For compound 3 the middle estimate is 1 percentage points above the measured one; low and high end bracket the measured number.
By their numbers in this assay, from the lowest: compounds 1, 3 and 2 (each within the scatter of the next).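

Bromo in place of chloro is a change between two halogens on the same aromatic carbon, ortho to a large group, and in this assay it gives a number 4 percentage points lower from compound 2 to compound 3 (within the scatter), while the pair with the tert-butyl compound gives a number 2 percentage points higher from compound 1 to compound 3 (within the scatter). Where the earlier compounds offered a single comparison at this position, tert-butyl, chloro and bromo now form a set of three whose printed steps all lie within the scatter, so none of these three groups can be separated from the others in this assay, and the statement holds for compounds 1, 2 and 3 only. Nothing available on these compounds speaks to why the read-out stays within the scatter across these exchanges.

Open, on these data alone, is whether an amine, a carboxylic acid or a longer chain on this aromatic carbon would give a step beyond the scatter. Also open, as far as these compounds go, is whether a chloro or bromo group placed elsewhere on the ring, or a change away from this ring in the shared core, would separate from compound 1 in this assay.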